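Trimethoxy chalcone series: aryl swap on the five-membered ring

This account rests on a few compounds, and the source may have more. Where it says the series, first, only, none or still open, it means among the compounds named here.

Measured so far:
compound 1 `COc1cc(/C=C/C(=O)c2cccc(-n3cc(-c4ccc(Cl)cc4)[nH]c3=O)c2)cc(OC)c1OC` 1390 nM
compound 2 `O=C(/C=C/c1cccc(O)c1)c1cccc(-n2cc(-c3ccccc3)[nH]c2=O)c1` 3020 nM
compound 3 `COc1ccc(-c2cn(-c3cccc(C(=O)/C=C/c4ccc(O)c(OC)c4)c3)c(=O)[nH]2)cc1` 1930 nM

In a functional assay on HCT-116 cells (Homo sapiens) for inhibition (on this read-out higher numbers stand for weaker inhibition of growth and lower numbers for stronger inhibition of growth), compound 1 gives 1390 nM, the lowest of the three numbers. Compound 3 gives 1930 nM, a reading within the scatter of compound 1, so no order between them is claimed. Compound 2 gives 3020 nM, which lies beyond the scatter above compound 1.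

Compound 4 `COc1cc(/C=C/C(=O)c2cccc(-n3cc(-c4cc(OC)c(OC)c(OC)c4)[nH]c3=O)c2)cc(OC)c1OC` differs from compound 1 by 3,4,5-trimethoxyphenyl in place of 4-chlorophenyl on an aromatic carbon. For the measured compounds named here, no measured pair isolates this change, so the step is expected to be small, with no direction beyond the scatter. Compound 4 is estimated at 2000 nM, range 700 nM to 6000 nM, which means an expected step of a 1.4-fold higher number from compound 1 to compound 4 (0.16 log units; within the scatter).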

Compound 4, concentration for 50% growth inhibition: 740 nM
Compound 4: middle estimate off by 2.7-fold (0.43 log units), on the high side; the range from low to high includes it.
By their numbers in this assay, from the lowest: compounds 4, 1, 3 and 2 (each within the scatter of the next, the first and the last beyond it).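

In this assay the step of a 1.9-fold lower number from compound 1 to compound 4 (0.27 log units; within the scatter) shows that this aromatic carbon of the five-membered ring carries 3,4,5-trimethoxyphenyl, with 12 heavy atoms against 7 for 4-chlorophenyl, without a change beyond the scatter. The earlier compounds shown here held no pair that isolated this position, so this is its first direct reading. No supporting data on this change are available.

Going by these compounds, whether an amine or a carboxylic acid on this phenyl group, or a longer chain in its place, would keep growth inhibition remains open. The reading also rests on a single pair, in one background.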